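Anilide series: chloroethyl amide in cellular inhibition assay

This account rests on a few compounds, and the source may have more. Where it says the series, first, only, none or still open, it means among the compounds named here.

Measured so far:
- compound 1, `C=CC(=O)Nc1cccc(-c2nc3ccccc3s2)c1`: > 25000 nM
- compound 2, `C/C=C/C(=O)Nc1cccc(-c2nc3ccccc3s2)c1`: > 25000 nM
- compound 3, `CN(C)CCC(=O)Nc1cccc(-c2nc3ccccc3s2)c1`: > 25000 nM

All three measurements come from an ADME assay on BJ cells (Homo sapiens) for inhibition, with a stated time of 72 h; a higher number here means that more compound is needed for the effect, a lower number that less compound is needed. In this assay compound 1 reaches only the limit > 25000 nM. Compound 2 likewise stands at the limit > 25000 nM. Compound 3 also stands at the limit > 25000 nM, so no number is known for it, only a boundary. Consequently the steps a step that the two limits leave unreadable from compound 1 to compound 2, a step that the two limits leave unreadable from compound 1 to compound 3 and a step that the two limits leave unreadable from compound 2 to compound 3 cannot be sized; the common feature is the limit of > 25000 nM in this assay, at which 3 of the 3 values shown sit.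

Compound 4, `CC(Cl)C(=O)Nc1cccc(-c2nc3ccccc3s2)c1`, has not yet been tested in this assay. Its difference from compound 3 is 1-chloroethyl in place of 2-(dimethylamino)ethyl on a carbonyl carbon. Among the measured compounds shown here, no measured step bears directly on this change, since every step between compounds 1, 2 and 3 is unreadable because of the limit of > 25000 nM in this assay, at which 3 of the 3 values shown sit. Three amide variants of differing character all failed to reach a readable value, and nothing among them indicates that the 1-chloroethyl amide would behave otherwise. The step from compound 3 to compound 4 is therefore expected to be a step that the limit leaves unreadable from compound 3 to compound 4, most probably ending again at the limit. For compound 4 in this assay the expected value is 30000 nM, within 8000 nM to 100000 nM.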

Compound 4, half-maximal effective concentration: > 25000 nM
Compound 4 was reported as a limit (the forecaster's own chance of this, stated with the estimate: 80%); the middle value does not contradict the limit.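

No step from compound 1, compound 2 or compound 3 to compound 4 can be read in this assay, because compound 4 also gives only a limit: the limit of > 25000 nM in this assay, at which 4 of the 4 values shown sit.

The compounds shown leave open whether any amide on the shared core reaches a readable half-maximal effective concentration in this assay, and how compounds 1 to 4 compare with one another.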